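The source may report more compounds than this note shows. Statements on the series, on what has been measured and on what is new or still open speak of the compounds shown alone.

Measured compounds in a functional assay on T47D cells (Homo sapiens) for cytotoxicity, read by CCK-8 assay and cell counting, with a stated time of 2 days; a higher number here means a weaker inhibitor, a lower number a stronger inhibitor:
- compound 1 `Oc1cccc(-c2cc(-c3ccncc3)nc(-c3ccccc3Cl)c2)c1`: compound 1 gives "not determined" (no result reported)
- compound 2 `Oc1cccc(-c2cc(-c3ccc(Cl)cc3)nc(-c3ccsc3)c2)c1`: compound 2 gives 11500 nM
- compound 3 `Oc1cccc(-c2cc(-c3ccccc3)nc(-c3ccc(Cl)cc3)c2)c1`: compound 3 gives 11300 nM

Going by the values given here, compound 3 holds the lower of the two numbers available, but its nearest neighbour is compound 2, and the one measured step, a 1.0-fold lower number from compound 2 to compound 3 (0.01 log units; within the scatter), lies within the scatter; the two compounds cannot be ordered on these data. Compound 1 carries the same pyridin-4-yl group that enters here, yet has no number, so it gives no guidance.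

Compound 4 `Oc1cccc(-c2cc(-c3ccncc3)nc(-c3ccc(Cl)cc3)c2)c1` differs from compound 3 in one place: pyridin-4-yl in place of phenyl on an aromatic carbon. Among the compounds with values here, no measured step covers this exchange, and the single step available concerns a different position on the shared core. With nothing pointing in either direction, no change beyond the scatter is expected in this assay, so compound 4 is estimated at about the level of compound 3, with a 1.0-fold lower number from compound 3 to compound 4 (0.01 log units; within the scatter) as the expected step. The estimate for compound 4 is 11000 nM, with a range from 4000 nM to 30000 nM.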

Compound 4, half-maximal inhibitory concentration: 3330 nM
Estimate against measurement, compound 4: 3.3-fold (0.52 log units) above; measured number outside the range, below it.
By their numbers in this assay, from the lowest: compound 4; then compounds 3 and 2 (each within the scatter of the next).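

In this assay, going by these compounds alone, this position proves sensitive to the ring exchanged: a 3.4-fold lower number from compound 3 to compound 4 (0.53 log units; beyond the scatter), whereas the only earlier step, a 1.0-fold lower number from compound 2 to compound 3 (0.01 log units; within the scatter), left the phenyl and thiophen-3-yl compounds inseparable. The second new step, a 3.5-fold lower number from compound 2 to compound 4 (0.54 log units; beyond the scatter), agrees with this, placing pyridin-4-yl apart from both other rings, though at a modest size. No supporting measurement is available to explain the difference.

Going by these compounds, whether the ring nitrogen must sit where it does in pyridin-4-yl remains open, as pyridin-3-yl, pyridin-2-yl or a 4-aminophenyl group would be needed to test this. On these data alone, compound 1 gives "not determined" (no result reported), so it also remains open whether the step carries over to the chlorophenyl arrangement in compound 1.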